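The source may report more compounds than this note shows. Statements on the series, on what has been measured and on what is new or still open speak of the compounds shown alone.

Measured so far:
- compound 1 `COc1ccc(/C=C2\CCC/C(=C\c3ccc(OC)cc3)C2=O)cc1`: 178000 nM
- compound 2 `O=C1/C(=C/c2cccc(Br)c2)CCC/C1=C\c1cccc(Br)c1`: 35900 nM
- compound 3 `COc1cccc(/C=C2\CCCCC2=O)c1OC`: 720000 nM

In an ADME assay on Vero cells (Chlorocebus sabaeus) for inhibition (on this read-out higher numbers stand for lower toxicity in this test and lower numbers for higher toxicity in this test), compound 1 stands second highest of the three, with compound 3 above it and compound 2 below it, both gaps beyond the usual scatter. Compound 4 `COc1ccc(/C=C2\CCC/C(=C\c3ccccc3)C2=O)cc1` differs from compound 1 by hydrogen in place of methoxy on an aromatic carbon, para to a large group: hydrogen in place of methoxy on an aromatic carbon. Among the compounds with values here, no measured pair isolates this change, so the only guide is the spread from compound 2 at 35900 nM to compound 3 at 720000 nM. The expected step of a 1.4-fold lower number from compound 1 to compound 4 (0.14 log units; within the scatter) is small and not beyond the scatter. For compound 4 the estimated value is 130000 nM, with an expected range of 55000 nM to 320000 nM.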

Compound 4, half-maximal cytotoxic concentration: 291000 nM
Compound 4: the middle estimate sits 2.2-fold (0.35 log units) below what was measured; low and high end bracket the measured number.
By their numbers in this assay, from the lowest: compound 2; then compounds 1 and 4 (each within the scatter of the next); then compound 3.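

In this assay, within the data shown here, hydrogen in place of methoxy on an aromatic carbon, para to a large group, gives a 1.6-fold higher number from compound 1 to compound 4 (0.21 log units; within the scatter), the first step that isolates a single change. The 4-methoxyphenyl to phenyl change at this position therefore leaves the number within the scatter. Nothing measured here bears on the reason for this step.

As far as these compounds go, whether an amine or a carboxylic acid at this position would move the number beyond the scatter stays open. Also open, from the compounds shown here alone, is what replacing the remaining methoxy of compound 4 with hydrogen would give.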